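The compounds below may be only part of what the source reports. "The series", "measured", "known", "first", "only" and "open" are said of these compounds alone.

The series rests on a shared core, carried by compound 1 `COc1ccc(-c2cnc(NC(=O)c3ccn[nH]3)n2C)cc1`, compound 2 `COc1ccc(-c2cnc(NC(=O)c3cccc(C#N)c3)n2C)cc1` and compound 3 `COc1ccc(-c2cnc(NC(=O)c3ccccc3)n2C)cc1`, which differ only in the group on the carbonyl carbon of the amide. In a toxicity assay on THP-1 cells (Homo sapiens) for inhibition (on this read-out higher numbers stand for lower toxicity in this test and lower numbers for higher toxicity in this test), compound 1 gives only a limit of the test, > 100000 nM. Compound 2 likewise gives only a limit in this assay, > 100000 nM. Compound 3 too stands at a limit in this assay, > 100000 nM. Within the data shown here, because of the limit of > 100000 nM in this assay, at which 3 of the 3 values shown sit, none of the measured steps can be read: the step that the two limits leave unreadable from compound 1 to compound 2, the step that the two limits leave unreadable from compound 1 to compound 3 and the step that the two limits leave unreadable from compound 2 to compound 3 all remain without a size.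

The next compound, compound 4 `COc1ccc(-c2cnc(NC(=O)c3cnco3)n2C)cc1`, carries a change at the same position as the earlier ones: 1,3-oxazol-5-yl in place of phenyl on a carbonyl carbon. The two steps that touch compound 3, from compound 1 and from compound 2, bear most directly on this change, yet both are unreadable, so no direction can be drawn from them. With every measured compound sitting at the limit, compound 3 serves as the reference and the expectation for compound 4 is that it also stays at or near that limit, with an expected step of a number no higher from compound 3 to compound 4 (the limit leaves the size open) that is no more than the scatter. Compound 4 is therefore estimated at 100000 nM, in a range from 50000 nM to 200000 nM.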

Compound 4, half-maximal cytotoxic concentration: > 100000 nM
Compound 4 was reported as a limit; the forecaster's own chance of this, stated with the estimate: 85%; the middle value lies on the limit itself.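

Compound 4 stands at the same limit as compound 1, compound 2 and compound 3, so none of the steps from these three compounds to compound 4 can be read: the limit of > 100000 nM in this assay, at which 4 of the 4 values shown sit.

The compounds shown leave open whether the group on the carbonyl carbon matters at all in this assay, and at what concentration any of these compounds would be toxic.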